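The compounds below may be only part of what the source reports. "The series", "measured", "known", "first", "only" and "open" are said of these compounds alone.

In an ADME assay on microsomes from liver (Homo sapiens) for pharmacokinetics (on this read-out lower numbers stand for slow clearance and higher numbers for fast clearance), compound 1 (`C[C@@H]1CN(c2nc(-c3cnn(C)c3)ncc2C#N)CCN1C(=O)C1(C)CC1`) gives < 16 mL/min/kg, which is a limit of this assay and not a number. Compound 2 (`C[C@@H]1CN(c2nc(-c3cnn(C)c3)ncc2C#N)CCN1C(=O)C1CCC1`) gives < 16 mL/min/kg, which is likewise a limit and not a number. Compound 2 therefore has no exact clearance to serve as a starting point, and the evidence amounts to the limit of < 16 mL/min/kg in this assay, at which 2 of the 2 values shown sit. Compound 3 (`C[C@@H]1CN(c2nc(-c3cnn(C)c3)ncc2C#N)CCN1C(=O)C1CC1`) differs from compound 2 in one place, on a carbonyl carbon whose other neighbours are: amide-type nitrogen in a ring. There, cyclopropyl stands in place of cyclobutyl: cyclopropyl in place of cyclobutyl on a carbonyl carbon. Going by the values given here, the only measured step that bears on this change is a step that the two limits leave unreadable from compound 1 to compound 2, which also alters the group on that carbonyl carbon but gives no readable size. With no measured size to carry over, no change beyond the usual scatter is expected in this assay, and a further limit is the likeliest report. The expected result is a step that the limit leaves unreadable from compound 2 to compound 3. For compound 3 the estimated clearance is 12 mL/min/kg, with an expected range of 6 mL/min/kg to 20 mL/min/kg.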

Compound 3, clearance: 21 mL/min/kg
Compound 3: middle estimate off by 1.8-fold (0.24 log units), on the low side; the whole stated range lies below it.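

In this assay, going by these compounds alone, compound 3 is the only one of the three compounds to carry a number and not a limit, so this position on the carbonyl carbon now yields steps with a readable direction. Cyclopropyl in place of cyclobutyl gives an at least 1.3-fold higher number from compound 2 to compound 3 (0.11 log units; that floor lies within the scatter), and hydrogen in place of methyl on a saturated ring carbon of the same group gives an at least 1.3-fold higher number from compound 1 to compound 3 (0.11 log units; that floor lies within the scatter). Both sizes are floors only, and the step between compound 1 and compound 2 cannot be read, since those two compounds stay at a limit: the limit of < 16 mL/min/kg in this assay, at which 2 of the 3 values shown sit.

As far as these compounds go, how far compound 1 and compound 2 actually lie from compound 3 stays open, and with it whether either change on the carbonyl carbon moves the clearance beyond the usual scatter at all. Also open, from the compounds shown here alone, is how an open chain such as isopropyl, an amine or an oxetanyl ring on that carbonyl carbon would read in this assay.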